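Chloropurines with chloromethylbenzyl groups: cytotoxicity notes

A few compounds are considered here, and "the series" means these few. Any claim that something is new, unique, unknown or untested is made for them only; others in the source may bear on it.

Measured in a functional assay on HCC 2998 cells (Homo sapiens) for cytotoxicity, read by sulforhodamine B assay, with a stated time of 48 h; a lower number here means that less compound is tolerated, a higher number that more compound is tolerated:
compound 1 `ClCc1ccccc1Cn1cnc2c(Cl)nc(Cl)nc21` gives 6160 nM
compound 2 `ClCc1ccccc1Cn1cnc2c(Cl)ncnc21` gives 7410 nM
compound 3 `ClCc1cccc(Cn2cnc3ncnc(Cl)c32)c1` gives 40700 nM

Between compound 2 and compound 1 the change is chloro in place of hydrogen on an aromatic carbon; it made a 1.2-fold lower number from compound 2 to compound 1 (0.08 log units; within the scatter). Compound 2 and compound 3 share the same atoms joined differently; the difference between the two cores is not broken down here. Compound 3 stands highest of the three numbers, beyond the scatter to compound 2 and to compound 1.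

Compound 4 `ClCc1cccc(Cn2cnc3nc(Cl)nc(Cl)c32)c1` is not yet measured. Relative to compound 3 the change is chloro in place of hydrogen on an aromatic carbon, the same change as from compound 2 to compound 1, at a place described in identical words. The expected step from compound 3 to compound 4 in this assay is therefore a 1.2-fold lower number from compound 3 to compound 4 (0.08 log units; within the scatter), beside the earlier 1.2-fold lower number from compound 2 to compound 1 (0.08 log units; within the scatter), on which the expectation rests. For compound 4 the estimate is 34000 nM, expected between 15000 nM and 75000 nM.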

Compound 4, concentration lethal to 50% of the cells: 5750 nM
Estimate against measurement, compound 4: 5.9-fold (0.77 log units) above; the whole stated range lies above it.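

In this assay, chloro in place of hydrogen on an aromatic carbon gave a 7.1-fold lower number from compound 3 to compound 4 (0.85 log units; beyond the scatter), and the change did not carry over with the same size from one core to the other: the same change on two cores in this assay, a 1.2-fold lower number (0.08 log units; within the scatter) from compound 2 to compound 1 and a 7.1-fold lower number (0.85 log units; beyond the scatter) from compound 3 to compound 4, 5.9-fold (0.77 log units) apart, beyond the scatter of two such steps

These two pairs show that the size of this step can differ between cores in this series, so a step read on one core is a poor guide to the other. They do not show what in the cores sets the difference, or how the step would run on any further core.

Open, from the compounds shown here alone, is whether an amine or a methoxy group at that aromatic carbon would also give a core-dependent step. Also open, going by these compounds, is how the two cores would compare with a hydroxymethyl group in place of the chloromethyl group.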